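A few compounds are considered here, and "the series" means these few. Any claim that something is new, unique, unknown or untested is made for them only; others in the source may bear on it.

In a functional assay on MCF7 cells (Homo sapiens) for cytotoxicity, read by MTT assay, with a stated time of 72 h (on this read-out higher numbers stand for weaker inhibition and lower numbers for stronger inhibition), three compounds sharing one core have been measured: compound 1 (`CN(C)CCCCCn1c2c(c3ccccc31)C(=O)c1c[n+]([O-])c3ccccc3c1C2=O`) gives 200 nM, compound 2 (`CN1CCN(CCCn2c3c(c4ccccc42)C(=O)c2c[n+]([O-])c4ccccc4c2C3=O)CC1`) gives 220 nM, and compound 3 (`O=C1c2c[n+]([O-])c3ccccc3c2C(=O)c2c1c1ccccc1n2CCN1CCCCC1`) gives 620 nM. Compound 3 has the highest number of the three and is thus the weakest. Compounds 1 and 2 do not separate, with a 1.1-fold higher number from compound 1 to compound 2 (0.04 log units; within the scatter).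

Compound 4 (`CN1CCN(CCCCCCn2c3c(c4ccccc42)C(=O)c2c[n+]([O-])c4ccccc4c2C3=O)CC1`) differs from compound 3 as follows: 4-(4-methylpiperazin-1-yl)butyl in place of piperidin-1-yl on a saturated chain carbon, two bonds along the chain from an aromatic nitrogen. In words, 4-(4-methylpiperazin-1-yl)butyl stands in place of piperidin-1-yl on a saturated chain carbon, two bonds along the chain from an aromatic nitrogen.

Among the measured compounds shown here, no measured step makes this exact change. The nearest are a 2.8-fold higher number from compound 2 to compound 3 (0.45 log units; beyond the scatter) and a 3.1-fold higher number from compound 1 to compound 3 (0.49 log units; beyond the scatter), both modest, and both lead to piperidin-1-yl, whereas compound 4 leaves it. Compound 2 also carries the 4-methylpiperazin-1-yl group. A modest step of similar size toward a lower number is therefore expected in this assay. The estimated change is a 3.0-fold lower number from compound 3 to compound 4 (0.47 log units; beyond the scatter). Compound 4 is estimated at 210 nM, with an expected range of 90 nM to 500 nM.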

Compound 4, half-maximal inhibitory concentration: 400 nM
Compound 4: middle estimate off by 1.9-fold (0.28 log units), on the low side; measured number inside the range.
By their numbers in this assay, from the lowest: compounds 1, 2, 4 and 3 (each within the scatter of the next, the first and the last beyond it).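

Carried on this saturated chain carbon, the 4-(4-methylpiperazin-1-yl)butyl group gives a compound that does not separate from any earlier one in this assay, with a 1.6-fold lower number from compound 3 to compound 4 (0.19 log units; within the scatter), a 1.8-fold higher number from compound 2 to compound 4 (0.26 log units; within the scatter) and a 2.0-fold higher number from compound 1 to compound 4 (0.30 log units; within the scatter). Compound 4 thus shows that the 4-methylpiperazin-1-yl group can sit on a longer chain than in compound 2 without a step beyond the scatter, and that leaving piperidin-1-yl here need not bring a clear separation from compound 3. Nothing measured on the compounds explains these results.

The step from compound 3 changes the ring and the chain together, so the compounds shown cannot apportion it between the two. Also open, going by these compounds, is how a morpholin-4-yl group, a primary amine or a still longer chain would behave at this position.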